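Swapping the Aryl Group on the Ring Nitrogen

The source may report more compounds than this note shows. Statements on the series, on what has been measured and on what is new or still open speak of the compounds shown alone.

Measured compounds:
compound 1 `CCNC(=O)c1cc(Oc2ccc(NC(=O)c3nn(-c4cccc(F)c4)c(=O)cc3C)cc2)ccn1`: 6870 nM
compound 2 `CCCNC(=O)c1cc(Oc2ccc(NC(=O)c3nn(-c4ccccc4OC(F)(F)F)c(=O)cc3C)cc2F)ccn1`: 3690 nM
compound 3 `CCCNC(=O)c1cc(Oc2ccc(NC(=O)c3nn(-c4ccc(Br)cc4F)c(=O)cc3C)cc2F)ccn1`: 53500 nM

In a functional assay on HeLa cells (Homo sapiens) for antiproliferative activity, read by MTT assay, with a stated time of 72 h (on this read-out higher numbers stand for weaker inhibition and lower numbers for stronger inhibition), compound 1 stands second highest of the three numbers; compound 2 lies within the scatter of it, while compound 3 lies beyond the scatter above it. Compound 4 `CCNC(=O)c1cc(Oc2ccc(NC(=O)c3nn(-c4ccc(C)cc4)c(=O)cc3C)cc2)ccn1` differs from compound 1 in one place: 4-methylphenyl in place of 3-fluorophenyl on an aromatic nitrogen. The one step shown on the same aromatic nitrogen, a 14-fold higher number from compound 2 to compound 3 (1.16 log units; beyond the scatter), shows that exchanging the aryl group there can move the number a great deal, but those two aryl groups differ from the ones here, and compounds 2 and 3 share a core that is not that of compound 1. No direction can be read from it, so a wide range is appropriate. Compound 4 is therefore expected at 7000 nM, from 1500 nM to 35000 nM, a step of a 1.0-fold higher number from compound 1 to compound 4 (0.01 log units; within the scatter).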

Compound 4, half-maximal inhibitory concentration: 10700 nM
Compound 4: the middle estimate sits 1.5-fold (0.18 log units) below what was measured; the range from low to high includes it.
By their numbers in this assay, from the lowest: compounds 2, 1 and 4 (each within the scatter of the next, the first and the last beyond it); then compound 3.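

On the core of compound 1, placing 4-methylphenyl on the aromatic nitrogen in place of 3-fluorophenyl gives, in this assay, a 1.6-fold higher number from compound 1 to compound 4 (0.19 log units; within the scatter). An aryl exchange at this position therefore need not produce a large step such as a 14-fold higher number from compound 2 to compound 3 (1.16 log units; beyond the scatter), although that step involves other aryl groups on another core. No measurement shown here bears on this result.

On these data alone, it remains open whether an amine or a carboxylic acid on the phenyl ring would stay within this range. As far as these compounds go, it is also open whether 4-methylphenyl and 3-fluorophenyl would remain this close on the core of compound 2.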